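Compound 4 against compound 2: the aryl amide end

This account rests on a few compounds, and the source may have more. Where it says the series, first, only, none or still open, it means among the compounds named here.

- compound 1 `CN(C)C(=O)c1cc2cnc(Nc3ccc(N)cn3)nc2n1C1CCCC1`: 61.5%
- compound 2 `CN(C)C(=O)c1cc2cnc(Nc3ccc(NC(=O)C4(C(=O)Nc5cccc(O)c5)CC4)cc3)nc2n1C1CCCC1`: 75.7%
- compound 3 `Nc1ccc(NC(=O)C2(C(=O)Nc3ccc(F)cc3)CC2)cc1F`: 36%

All three values come from a functional assay on SiHa cells (Homo sapiens) for inhibition, read by CCK-8 assay, with a stated time of 72 h, tested at 10 uM; a lower number here means less inhibition of growth, a higher number more inhibition of growth at the concentration tested. In this assay compound 2, at 75.7%, stands highest of the three, and the gaps down to compound 1 and compound 3 both lie beyond the scatter.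

The next compound to be measured is compound 4 `CN(C)C(=O)c1cc2cnc(Nc3ccc(NC(=O)C4(C(=O)Nc5ccc(Cl)c(C(F)(F)F)c5)CC4)cc3)nc2n1C1CCCC1`. It departs from compound 2 in one place: 4-chloro-3-(trifluoromethyl)phenyl in place of 3-hydroxyphenyl on an amide-type nitrogen. The core and the rest of the chain stay the same.

For the measured compounds named here, no pair of measured compounds differs at this place alone, so no measured step guides the size or direction of the change. The starting point remains compound 2 at 75.7%. The expected change is a number 3.7 percentage points lower from compound 2 to compound 4 (within the scatter), a slight fall that is not expected to go beyond the scatter. For compound 4 the estimated value is 72%, with an expected range from 52% to 90%.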

Compound 4, percent growth inhibition at one concentration: 61.1%
Compound 4: the middle estimate sits 10.9 percentage points above what was measured, and the stated range covers the measured number.
By their numbers in this assay, from the lowest: compound 3; then compounds 4 and 1 (each within the scatter of the next); then compound 2.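

In this assay, this position on the amide-type nitrogen does respond to the aryl group it carries: 4-chloro-3-(trifluoromethyl)phenyl in place of 3-hydroxyphenyl gives a number 14.6 percentage points lower from compound 2 to compound 4 (beyond the scatter). For the compounds shown here, this is the first step read at this place, and it shows that the shared core and the rest of the chain do not alone fix the growth inhibition at the level of compound 2, 75.7%. No measurement shown here explains the fall.

Going by these compounds alone, the single step swaps the hydroxyl for both chlorine and trifluoromethyl, so it leaves their separate contributions unresolved. Also open, on these data alone, is how an unsubstituted phenyl, or a phenyl carrying an amine or a carboxylic acid, would compare on the same nitrogen.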